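The source may report more compounds than this note shows. Statements on the series, on what has been measured and on what is new or still open speak of the compounds shown alone.

Compound 2 `Fc1ccccc1Cn1nnc2c(NC3CCCCC3)nc(-c3ccccc3)nc21` gives 1150000 nM in an assay on isolated protein for binding affinity to adenosine receptor A1 (Bos taurus) (on this read-out higher numbers stand for weaker inhibition and lower numbers for stronger inhibition), and stands lowest of the three measured numbers. Compound 1 `FC(F)(F)c1ccccc1Cn1nnc2c(NC3CCCCC3)nc(-c3ccccc3)nc21` gives 6800000 nM in this assay, and compound 3 `Clc1ccccc1Cn1nnc2c(NC3CCCCC3)nc(-c3ccccc3)nc21` gives 34000000 nM in this assay. All three measured steps change a group on an aromatic carbon: a 5.9-fold lower number from compound 1 to compound 2 (0.77 log units; beyond the scatter); a 5.0-fold higher number from compound 1 to compound 3 (0.70 log units; beyond the scatter); a 30-fold higher number from compound 2 to compound 3 (1.47 log units; beyond the scatter).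

Compound 4 `OC1CCC(Nc2nc(-c3ccccc3)nc3c2nnn3Cc2ccccc2F)CC1` differs from compound 2 in another place altogether: hydroxy in place of hydrogen on a saturated ring carbon. For the measured compounds named here, none of the measured steps touches the saturated ring, so none of them bears on this change, and the series gives no guide to its size or direction. The working expectation is therefore no step beyond the scatter in this assay, held with wide uncertainty. For compound 4 the step is estimated as a 1.2-fold lower number from compound 2 to compound 4 (0.06 log units; within the scatter). Compound 4 is expected to give about 1000000 nM in this assay, within a range of 200000 nM to 5000000 nM. With numbers this weak, a limit rather than a number is a real possibility.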

Compound 4, inhibition constant: 1850000 nM
The estimate for compound 4 lay 1.9-fold (0.27 log units) below the measured number; measured number inside the range.
By their numbers in this assay, from the lowest: compounds 2 and 4 (each within the scatter of the next); then compound 1; then compound 3.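

Cyclohexyl to 4-hydroxycyclohexyl is the first change at the saturated ring in this series, and in this assay it is read as a 1.6-fold higher number from compound 2 to compound 4 (0.21 log units; within the scatter) without any step beyond the scatter. This ring carbon, three ring bonds from the ring atom that bears a large group, therefore accepts hydroxy in place of hydrogen with the two values within the scatter of each other, whereas all three earlier steps, on an aromatic carbon, lay beyond the scatter. Nothing in hand explains this result.

Still open, on these data alone, is whether an amine or a carboxylic acid on this ring carbon, or a longer chain in place of cyclohexyl, would also stay within the scatter of compound 2. Also open, as far as these compounds go, is whether hydroxy gives the same result alongside the trifluoromethyl of compound 1 or the chloro of compound 3.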